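The source may report more compounds than this note shows. Statements on the series, on what has been measured and on what is new or still open speak of the compounds shown alone.

Measured compounds:
- Compound 1 `COc1cc(-c2cc(/C=C/C(=O)c3ccc(N)cc3)[nH]n2)cc(OC)c1OC`: 13400 nM
- Compound 2 `COc1ccc(-c2cc(/C=C/C(=O)c3ccc(N)cc3)[nH]n2)cc1OC`: 41300 nM

In a functional assay on SN12C cells (Homo sapiens) for inhibition, read by sulforhodamine B assay, with a stated time of 48 h (a lower number here means that less compound is tolerated, a higher number that more compound is tolerated), compound 1 gives the lower of the two numbers, so less of it is tolerated by the cells than of compound 2; the gap is a 3.1-fold higher number from compound 1 to compound 2 (0.49 log units; beyond the scatter), and it comes from a hydrogen in place of methoxy on an aromatic carbon. Compound 3 `COc1cc(-c2cc(/C=C/C(=O)c3ccc(F)c(F)c3)[nH]n2)cc(OC)c1OC` is not yet measured. It differs from compound 1 at the other end of the molecule: 3,4-difluorophenyl in place of 4-aminophenyl on a carbonyl carbon. Going by the values given here, no measured step touches this side, since the only known step alters the aromatic ring at the far end, so it offers no guide to the size or direction of the change. The expectation for compound 3 is therefore a step of a 1.1-fold higher number from compound 1 to compound 3 (0.05 log units; within the scatter), essentially no move beyond the scatter, with wide uncertainty. Compound 3 is estimated at 15000 nM, within 4000 nM to 55000 nM.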

Compound 3, concentration lethal to 50% of the cells: > 100000 nM
Compound 3: only a limit was reported; the forecaster's own chance of this, stated with the estimate: 10%; at least 6.6-fold (0.82 log units) between middle value and limit.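

In this assay compound 3 gives > 100000 nM, which is a limit of the assay and not a number: the limit of > 100000 nM in this assay, at which 1 of the 3 values shown sits. Placing 3,4-difluorophenyl instead of 4-aminophenyl on the carbonyl carbon gives an at least 7.4-fold higher number from compound 1 to compound 3 (0.87 log units; beyond the scatter), with more compound tolerated by the cells. Going by these compounds alone, this is the first evidence that the group at this position can shift the result, as the only earlier step was hydrogen in place of methoxy on an aromatic carbon.

The change removes the amine and adds two fluorines in a single step, and the compounds shown cannot separate these two parts of it. Going by these compounds, how a plain phenyl, or a ring carrying a hydroxyl or a methyl, would behave at this position remains open, as does how far above the limit compound 3 lies.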